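A Small Swap on Compound 2: Methyl to Methoxy

A few compounds are considered here, and "the series" means these few. Any claim that something is new, unique, unknown or untested is made for them only; others in the source may bear on it.

Measured so far:
compound 1 `O=C(O)/C=C/c1ccc(Cn2cccn2)cc1OCCc1ccc2ccccc2c1` – 12 nM
compound 2 `Cc1ccc(/C=C/C(=O)O)c(OCCC2(C)CCc3c(C)c(O)c(C)c(C)c3O2)c1` – 940 nM

In an assay on CHO cells for displacement of a labelled ligand from prostaglandin E2 receptor EP3 subtype (Mus musculus), read by scintillation counting (a higher number here means a weaker inhibitor, a lower number a stronger inhibitor), compound 1 gives 12 nM and compound 2 gives 940 nM. Compound 2 thus stands highest of the two numbers, and its gap to compound 1 lies beyond the scatter. Compound 3 `COc1ccc(/C=C/C(=O)O)c(OCCC2(C)CCc3c(C)c(O)c(C)c(C)c3O2)c1` has not been measured; it differs from compound 2 only in methoxy in place of methyl on an aromatic carbon. Among the measured compounds shown here, no measured pair shows this change, so nothing here tells its effect. Compound 3 is therefore expected to stay near compound 2. The expected step is a 1.3-fold lower number from compound 2 to compound 3 (0.10 log units; within the scatter), not beyond the scatter. For compound 3 the estimate is 750 nM, within 250 nM to 2500 nM.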

Compound 3, inhibition constant: > 10000 nM
Compound 3: only a limit was reported; the forecaster's own chance of this, stated with the estimate: 5%; at least 13-fold (1.12 log units) between middle value and limit.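

Swapping methyl for methoxy at this place, para to the 2-carboxyethenyl group, gives an at least 10-fold higher number from compound 2 to compound 3 (1.02 log units; beyond the scatter) in this assay. Among the compounds shown here, this is the first single change seen here, and it shows that binding can depend heavily on the group at this position, even when only one oxygen atom is added. For compound 3, > 10000 nM is a limit of the assay, not a number.

The compounds shown leave open how an ethyl group, a fluorine or a hydroxyl would fare at this position. They also leave open whether a bare hydrogen there would match compound 2.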